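Benzothiazole amide series: fluoro to methoxy on the benzothiazole

The source may report more compounds than this note shows. Statements on the series, on what has been measured and on what is new or still open speak of the compounds shown alone.

Measured compounds:
compound 1 `COc1ccc(-c2cc(C(=O)Nc3nc4ccc(F)cc4s3)nc3cc(-c4ccccc4)nn23)cc1`, in a functional assay on DU-145 cells (Homo sapiens) for cytotoxicity, read by MTT assay, with a stated time of 48 h (on this read-out higher numbers stand for weaker inhibition and lower numbers for stronger inhibition), compound 1 gives 31400 nM
compound 2 `COc1ccc(-c2cc(C(=O)Nc3nc4ccc(F)cc4s3)nc3cc(-c4ccccc4)nn23)cc1OC`, in this assay compound 2 gives 18600 nM
compound 3 `COc1cc(-c2cc(C(=O)Nc3nc4ccc(F)cc4s3)nc3cc(-c4ccccc4)nn23)cc(OC)c1OC`, in this assay compound 3 gives 25700 nM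

Compound 3 sits in one cluster with the other two: a 1.2-fold lower number from compound 1 to compound 3 (0.09 log units; within the scatter) and a 1.4-fold higher number from compound 2 to compound 3 (0.14 log units; within the scatter), both within the scatter, as is a 1.7-fold lower number from compound 1 to compound 2 (0.23 log units; within the scatter). The three numbers show no separation.

Compound 4 `COc1ccc2nc(NC(=O)c3cc(-c4cc(OC)c(OC)c(OC)c4)n4nc(-c5ccccc5)cc4n3)sc2c1` differs from compound 3 by methoxy in place of fluoro on an aromatic carbon. For the measured compounds named here, none of the measured steps touches this ring: all three concern methoxy groups on the other aryl ring of the shared core, and each stayed within the scatter. Going by the values given here, there is no direct precedent for the change on the 6-fluoro-1,3-benzothiazol-2-yl group, so the expectation rests on the flat behaviour of the series so far.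

The step from compound 3 to compound 4 in this assay is expected to be a 1.0-fold lower number from compound 3 to compound 4 (0.01 log units; within the scatter), within the scatter, in no clear direction. Compound 4 is therefore estimated at 25000 nM, with a range from 8000 nM to 70000 nM.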

Compound 4, half-maximal inhibitory concentration: 3980 nM
For compound 4 the middle estimate is 6.3-fold (0.80 log units) above the measured one, outside the stated range (below it).
By their numbers in this assay, from the lowest: compound 4; then compounds 2, 3 and 1 (each within the scatter of the next).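

For the compounds shown here, the 6-fluoro-1,3-benzothiazol-2-yl group is the first place where a single change moves the number in this assay beyond the scatter: methoxy in place of fluoro gives (a 6.5-fold lower number from compound 3 to compound 4 (0.81 log units; beyond the scatter)), while the steps among the methoxy groups on the other aryl ring all stayed within it. The read-out therefore responds to this position, though this rests on one pair, with the 3,4,5-trimethoxyphenyl group in place. No measurement shown here accounts for the step.

As far as these compounds go, whether methoxy itself matters or the loss of fluoro is enough remains open, as does what hydrogen, chloro or an amine would give on this carbon. Also open, from the compounds shown here alone, is whether the same change would carry over to compound 1 and compound 2.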